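Replacing dimethylamino with piperidinyl on the propyl chain

The source may report more compounds than this note shows. Statements on the series, on what has been measured and on what is new or still open speak of the compounds shown alone.

Compound 2 `CN(C)CCCn1cc(C2=C(Nc3ccccc3)C(=O)NC2=O)c2ccccc21` gives 3460 nM in an assay on isolated protein for inhibition of protein kinase C epsilon type (Homo sapiens); on this read-out higher numbers stand for weaker inhibition and lower numbers for stronger inhibition. Compound 3 `Cc1cccc(NC2=C(c3cn(CCCN(C)C)c4ccccc34)C(=O)NC2=O)c1` gives 3460 nM in this assay, and the step of no change at the digits printed from compound 2 to compound 3 (within the scatter) leaves compound 2 level with compound 3. Compound 1 `CN(C)CCn1cc(C2=C(Nc3ccccc3)C(=O)NC2=O)c2ccccc21` gives only a limit of this assay, > 10000 nM. Going by the values given here, the step of an at least 2.8-fold lower number from compound 1 to compound 2 (0.46 log units; beyond the scatter) is the only measured change at the chain end (the limit of > 10000 nM in this assay, at which 1 of the 3 values shown sits).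

Compound 4 `O=C1NC(=O)C(c2cn(CCCN3CCCCC3)c3ccccc23)=C1Nc1ccccc1` differs from compound 2 by piperidin-1-yl in place of dimethylamino on a saturated chain carbon, three bonds along the chain from an aromatic nitrogen. Among the compounds with values here, no measured step swaps the amine itself; the one chain-end step concerned length, not the amine. Compound 4 is therefore expected to show no step beyond the scatter, a 1.4-fold lower number from compound 2 to compound 4 (0.14 log units; within the scatter). The estimate for compound 4 is 2500 nM, expected between 800 nM and 8000 nM.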

Compound 4, half-maximal inhibitory concentration: 3430 nM
The estimate for compound 4 lay 1.4-fold (0.14 log units) below the measured number; measured number inside the range.
By their numbers in this assay, from the lowest: compounds 4, 2 and 3 (each within the scatter of the next). At a limit, above all of these: compound 1.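

Swapping the amine itself at the end of the propyl chain gives a 1.0-fold lower number from compound 2 to compound 4 (0.00 log units; within the scatter) in this assay, so the larger piperidin-1-yl ring and dimethylamino read alike at this position. Starting instead from the shorter chain gives an at least 2.9-fold lower number from compound 1 to compound 4 (0.46 log units; beyond the scatter). Compound 1 stands at a limit of the assay, not at a number: the limit of > 10000 nM in this assay, at which 1 of the 4 values shown sits.

The compounds shown leave open whether an amine of another kind at this chain end, such as morpholin-4-yl or a primary amine, would read differently. They also leave open how a carboxylic acid there or a longer chain would read.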